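The compounds below may be only part of what the source reports. "The series", "measured", "known", "first", "only" and "open" are said of these compounds alone.

Compound 1 `Cc1cc(C)c(NC(=O)N(Cc2ccc(N3CCN(C)CC3)cc2)C2CCCCCC2)c(C)c1`, compound 2 `Cc1cc(C)c(NC(=O)N(Cc2ccc(-c3cc[nH]n3)cc2)C2CCCCCC2)c(C)c1` and compound 3 `Cc1cc(C)c(NC(=O)N(Cc2ccc(-c3cn[nH]c3)cc2)C2CCCCCC2)c(C)c1` share one core and differ only in the group on the outer benzene ring. In a functional assay on a cell-free system (plasma) with sterol O-acyltransferase, Soat (Rattus norvegicus) as the target (on this read-out higher numbers stand for an effect only at larger amounts of compound and lower numbers for an effect already at smaller amounts), compound 1 gives only a limit, > 1 mg/kg, not a number. Compound 2 likewise gives only a limit, > 1 mg/kg. Compound 3 also gives only a limit, > 1 mg/kg. Because (the limit of > 1 mg/kg in this assay, at which 3 of the 3 values shown sit), the steps a step that the two limits leave unreadable from compound 1 to compound 2, a step that the two limits leave unreadable from compound 1 to compound 3 and a step that the two limits leave unreadable from compound 2 to compound 3 cannot be sized. Compound 4 `Cc1cc(C)c(NC(=O)N(Cc2ccc(-n3nccn3)cc2)C2CCCCCC2)c(C)c1` differs from compound 3 by 2H-1,2,3-triazol-2-yl in place of 1H-pyrazol-4-yl on an aromatic carbon. Among the compounds with values here, no measured step reads out, so nothing points to a step beyond the scatter in this assay. The step expected is a step that the limit leaves unreadable from compound 3 to compound 4. The value expected for compound 4 is 1.5 mg/kg, with a range from 0.5 mg/kg to 5 mg/kg, and most likely again only a limit.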

Compound 4, dose for half-maximal effect: > 1 mg/kg
Compound 4 was reported as a limit; the forecaster's own chance of this, stated with the estimate: 75%; the middle value lies beyond the limit too.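

The steps from compound 1, compound 2 and compound 3 to compound 4 cannot be read, because all four compounds give only a limit: the limit of > 1 mg/kg in this assay, at which 4 of the 4 values shown sit. The compounds shown leave open what dose gives half-maximal effect in this assay, and whether these groups on the outer benzene ring differ at all.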